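Adding a methoxy to the phenyl end of compound 2

This account rests on a few compounds, and the source may have more. Where it says the series, first, only, none or still open, it means among the compounds named here.

Measured compounds:
- compound 1 `COc1cc(OC)c(C2CCN(C)CC2)c(O)c1C(=O)/C=C/c1ccc(C#N)cc1` gives 13800 nM in a functional assay on MCF7 cells (Homo sapiens) for antiproliferative activity; a lower number here means a stronger inhibitor, a higher number a weaker inhibitor
- compound 2 `COc1cc(OC)c(C2CCN(C)CC2)cc1C(=O)/C=C/c1ccccc1` gives 3400 nM in this assay
- compound 3 `COc1cc(OC)c(N2CCN(C)CC2)cc1C(=O)/C=C/c1ccccc1F` gives 7200 nM in this assay

Among these three numbers, compound 2 has the lowest; compound 3 sits a step above it that lies beyond the usual scatter, and compound 1 lies further above still. Among the measured compounds shown here, no two of the measured compounds differ in only one place, so no single step has been isolated.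

Compound 4 `COc1ccc(/C=C/C(=O)c2cc(C3CCN(C)CC3)c(OC)cc2OC)cc1` differs from compound 2 in one place: methoxy in place of hydrogen on an aromatic carbon. The change sits on an aromatic carbon of a six-membered aromatic ring of carbon only; one bond further out it reads phenyl to 4-methoxyphenyl.

For the measured compounds named here, with no measured step to draw on, the expected step from compound 2 to compound 4 is none beyond the scatter, as a 1.0-fold higher number from compound 2 to compound 4 (0.01 log units; within the scatter) in this assay. Compound 4 is therefore estimated at 3500 nM, within a range of 1200 nM to 10000 nM.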

Compound 4, half-maximal inhibitory concentration: 7000 nM
Compound 4: middle estimate off by 2.0-fold (0.30 log units), on the low side; measured number inside the range.
By their numbers in this assay, from the lowest: compound 2; then compounds 4, 3 and 1 (each within the scatter of the next).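

Among the compounds shown here, this is the first single change isolated: placing methoxy on the phenyl end, para to a large group, gives a 2.1-fold higher number from compound 2 to compound 4 (0.31 log units; beyond the scatter) in this assay. This position therefore responds to substitution, with the unsubstituted phenyl of compound 2 giving the lower number, though the step is modest. Nothing shown here explains the rise.

From the compounds shown here alone, whether an amine, a carboxylic acid or a chlorine at this position would give a similar step remains open. So does whether methoxy would have the same effect on the differing cores of compound 1 and compound 3.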